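Aryl Replacement at the Ether and Prostacyclin Synthase Inhibition

This account rests on a few compounds, and the source may have more. Where it says the series, first, only, none or still open, it means among the compounds named here.

Measured in an assay for inhibition of prostacyclin synthase (Homo sapiens), using microsomes; on this read-out lower numbers stand for stronger inhibition and higher numbers for weaker inhibition:
Compound 1 `N#Cc1ccccc1C1OCC(C/C=C\CCC(=O)O)C(c2cccnc2)O1` reaches only a limit, > 100000 nM (the limit of > 100000 nM in this assay, at which 1 of the 3 values shown sits).
Compound 2 `O=C(O)CC/C=C\CC1COC(c2ccc([N+](=O)[O-])cc2)OC1c1cccnc1` gives 13000 nM.
Compound 3 `CC(C)(Oc1ccccc1)C1OCC(C/C=C\CCC(=O)O)C(c2cccnc2)O1` gives 75000 nM.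

Compound 3 stands highest of the two numbers; its nearest neighbour is compound 2, and that gap is a 5.8-fold higher number from compound 2 to compound 3 (0.76 log units; beyond the scatter). Compound 4 `CSc1ccc(OC(C)(C)C2OCC(C/C=C\CCC(=O)O)C(c3cccnc3)O2)c([N+](=O)[O-])c1` differs from compound 3 by a group of 11 heavy atoms (7 carbon, 1 nitrogen, 2 oxygen, 1 sulfur; one six-membered aromatic ring of carbon only) in place of a group of 6 heavy atoms (6 carbon; one six-membered aromatic ring of carbon only), on an oxygen on a saturated carbon, on an oxygen on a saturated carbon whose other neighbours are a saturated chain carbon. The measured steps both change a substituent on a saturated ring carbon, a different place: an at least 7.6-fold lower number from compound 1 to compound 2 (0.88 log units; beyond the scatter) and a 5.8-fold higher number from compound 2 to compound 3 (0.76 log units; beyond the scatter). They show that changing an aromatic substituent can move the number beyond the scatter, so a modest shift to a lower number is expected for compound 4, a 3.8-fold lower number from compound 3 to compound 4 (0.57 log units; beyond the scatter). Compound 4 is estimated at 20000 nM, in the range 4000 nM to 100000 nM.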

Compound 4, half-maximal inhibitory concentration: 5000 nM
Beside the measured number, compound 4's estimate is 4.0-fold (0.60 log units) above it, within the range that was stated.
By their numbers in this assay, from the lowest: compound 4; then compound 2; then compound 3. At a limit, above all of these: compound 1.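

Swapping the phenyl on the oxygen for a larger aromatic group of 11 heavy atoms gives a 15-fold lower number from compound 3 to compound 4 (1.18 log units; beyond the scatter). Among the compounds shown here, the earlier steps changed a substituent on a saturated ring carbon, so this is the first sign that the aromatic group on the oxygen also matters, and strongly. Nothing shown here gives a reason for the drop.

On these data alone, the entering group adds several atoms at once, so which of them carries the change stays open. Whether a lone amine or a single fluorine on that phenyl would do the same is also unknown.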